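The source may hold more compounds than are shown below. What is called first, only, known or untested is meant among the compounds shown, and "the series" means these compounds.

Measured in a functional assay on PC-3 cells (Homo sapiens) for cytotoxicity, read by colorimetric assay; a higher number here means a weaker inhibitor, a lower number a stronger inhibitor:
- compound 1 `O=C(/C=C/c1ccc(CN2C(=O)/C(=C3\Nc4ccccc4\C3=N/O)c3cc(Cl)ccc32)cc1)NO` gives 60 nM
- compound 2 `COc1ccc2c(c1)/C(=C1/Nc3ccccc3/C1=N\O)C(=O)N2Cc1ccc(/C=C/C(=O)NO)cc1` gives 30 nM
- compound 3 `COc1ccc2c(c1)/C(=C1/Nc3ccccc3/C1=N\O)C(=O)N2Cc1ccc(C(=O)NO)cc1` gives 30 nM

In this assay compound 2 stands level with compound 3 at the digits shown. Next is compound 4 `O=C(/C=C/c1ccc(CN2C(=O)/C(=C3\Nc4ccccc4\C3=N/O)c3ccccc32)cc1)NO`, which differs from compound 2 as follows: hydrogen in place of methoxy on an aromatic carbon. This puts hydrogen in place of methoxy on an aromatic carbon. The change at this carbon in the measured set is a 2.0-fold lower number from compound 1 to compound 2 (0.30 log units; within the scatter), within the scatter. The change elsewhere, no change at the digits printed from compound 2 to compound 3 (within the scatter), is also within the scatter and bears on this change only weakly. Within the data shown here, no measured compound carries hydrogen here, so the direction is uncertain. The expected result is a 1.5-fold higher number from compound 2 to compound 4 (0.18 log units; within the scatter), with nothing expected beyond the scatter. For compound 4 the estimate is 45 nM, with an expected range from 18 nM to 110 nM.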

Compound 4, half-maximal inhibitory concentration: 50 nM
Compound 4: middle estimate off by 1.1-fold (0.05 log units), on the low side, and the stated range covers the measured number.
By their numbers in this assay, from the lowest: compounds 2, 3, 4 and 1 (each within the scatter of the next).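

In this assay hydrogen now joins chloro and methoxy on this aromatic carbon, with a 1.7-fold higher number from compound 2 to compound 4 (0.22 log units; within the scatter) and a 1.2-fold lower number from compound 1 to compound 4 (0.08 log units; within the scatter) both within the scatter. Even with no substituent on this carbon, compound 4 is not separated from compound 2 or compound 1, so none of the three groups is set apart here. Nothing available explains these steps. Still open, as far as these compounds go, is whether an amine, a carboxylic acid or a longer alkoxy chain on this carbon would give a step beyond the scatter.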